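The source may hold more compounds than are shown below. What is called first, only, known or untested is meant among the compounds shown, and "the series" means these compounds.

Two compounds of the series carry numbers in a functional assay on MCF7 cells (Homo sapiens) for inhibition; a lower number here means a stronger inhibitor, a higher number a weaker inhibitor. Compound 1 `CCn1c(=O)/c(=C2\Sc3ccccc3N2C)s/c1=C\c1ccncc1Nc1ccccc1C` gives 990 nM, the lower of the two numbers; compound 2 `CCc1ccc2c(c1)S/C(=c1/s/c(=C\c3ccncc3Nc3ccccc3F)n(CC)c1=O)N2C` gives 1200 nM, and the gap between them lies within the scatter, so neither stands apart. Compound 3 `CCn1c(=O)/c(=C2\Sc3ccccc3N2C)s/c1=C\c1ccncc1Nc1cc(C)ccc1C` is not yet measured; its change from compound 1 is methyl in place of hydrogen on an aromatic carbon. Among the compounds with values here, no measured pair shows this change, so its effect is unknown here; the expected step from compound 1 to compound 3 is one within the scatter, in no settled direction. Compound 3 is therefore expected near 900 nM in this assay, within 400 nM to 2000 nM. The step this estimate implies is a 1.1-fold lower number from compound 1 to compound 3 (0.04 log units; within the scatter), expected to stay within the scatter.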

Compound 3, half-maximal inhibitory concentration: 1700 nM
Estimate against measurement, compound 3: 1.9-fold (0.28 log units) below; low and high end bracket the measured number.
By their numbers in this assay, from the lowest: compounds 1, 2 and 3 (each within the scatter of the next).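

In this assay, methyl in place of hydrogen on this aromatic carbon, para to the existing methyl group, gives a 1.7-fold higher number from compound 1 to compound 3 (0.23 log units; within the scatter). Within the data shown here, the 2,5-dimethylphenyl group of compound 3 thus gives the first reading at this position, and the added methyl produces no step beyond the scatter. No supporting data bear on the reason for this result.

Open, on these data alone, is whether a methoxy group, a carboxylic acid or an amine at this carbon would also stay within the scatter. Also open, as far as these compounds go, is how methyl behaves on the other carbons of this ring.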